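Adding a Methoxy Group to a Compound with Low Inhibition

A few compounds are considered here, and "the series" means these few. Any claim that something is new, unique, unknown or untested is made for them only; others in the source may bear on it.

Compound 1 `Brc1cn2ccnc2c(-c2ccc3ncn(C4CCCCC4)c3c2)n1` and compound 2 `c1ccc(-c2cn3ccnc3c(-c3ccc4ncn(C5CCCCC5)c4c3)n2)cc1` share a core and differ only where one carries a bromo group and the other a phenyl group. In a functional assay on TK-10 cells (Homo sapiens) for inhibition, read by sulforhodamine B assay, with a stated time of 48 h, tested at 10 uM (a higher number here means more inhibition at the concentration tested (going by the name of the read-out), a lower number less inhibition), compound 1 gives 5.55%, and compound 2 gives 2.26%. For the measured compounds named here, the single measured step, a number 3.3 percentage points lower from compound 1 to compound 2 (within the scatter), lies within the scatter, so both compounds sit together at the low end of the scale, showing little inhibition at the concentration tested.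

Compound 3 `COc1ccc(-c2cn3ccnc3c(-c3ccc4ncn(C5CCCCC5)c4c3)n2)cc1` extends compound 2 by one change: methoxy in place of hydrogen on an aromatic carbon. Going by the values given here, no measured step involves a methoxy group, so the only guide is that the one step recorded, from bromo to phenyl, changed nothing beyond the scatter. Compound 3 is therefore expected to show a step of a number 0.7 percentage points higher from compound 2 to compound 3 (within the scatter), meaning no change beyond the scatter. The estimate for compound 3 is 3%, with a range from -6% to 12%.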

Compound 3, a percentage reported as inhibition, at one concentration (the size of the read-out at that concentration, not a potency): 18.5%
For compound 3 the middle estimate is 15.5 percentage points below the measured one; measured number above the stated range.
By their numbers in this assay, from the lowest: compounds 2 and 1 (each within the scatter of the next); then compound 3.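

In this assay, for the compounds shown here, methoxy on the phenyl group, para to a large group, gives the first step beyond the scatter, a number 16.2 percentage points higher from compound 2 to compound 3 (beyond the scatter), so this position does respond to a small substituent. Phenyl in place of bromo had left the number within the scatter, whereas 4-methoxyphenyl in place of bromo gives a number 13 percentage points higher from compound 1 to compound 3 (beyond the scatter), so among these three compounds only the one carrying the methoxy group stands apart. No measurement shown here explains this rise.

These compounds leave open whether the rise belongs to methoxy in particular or would also appear with a hydroxyl group, an amine or a longer ether chain at the same place. They also leave open how inhibition would change at other concentrations, since a single-concentration read-out is not a potency.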